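Replacing 2-hydroxyphenyl with 2,4-dichlorophenyl

A few compounds are considered here, and "the series" means these few. Any claim that something is new, unique, unknown or untested is made for them only; others in the source may bear on it.

Measured in a functional assay on LOX IMVI cells (Homo sapiens) for inhibition, read by sulforhodamine B assay, with a stated time of 48 h; on this read-out lower numbers stand for stronger inhibition of growth and higher numbers for weaker inhibition of growth:
- compound 1 `O=C(Cc1csc2nc(-c3ccc(Br)cc3)cn12)N/N=C/c1ccccc1O`: 3470 nM
- compound 2 `COc1cccc(OC)c1/C=N/NC(=O)Cc1csc2nc(-c3ccc(Br)cc3)cn12`: 12600 nM

Of these two compounds, compound 1 has the lower number and therefore the stronger growth inhibition, and the gap to compound 2 is beyond the scatter. The next compound to be tested is compound 3 `O=C(Cc1csc2nc(-c3ccc(Br)cc3)cn12)N/N=C/c1ccc(Cl)cc1Cl`. It keeps the core of compound 1 but carries 2,4-dichlorophenyl in place of 2-hydroxyphenyl on a carbon with a double bond to nitrogen.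

Among the compounds with values here, only one measured step bears on this change: a 3.6-fold higher number from compound 1 to compound 2 (0.56 log units; beyond the scatter). That step also removed the 2-hydroxyphenyl from the same place, and the number rose by a modest amount. Within the data shown here, no measured compound carries 2,4-dichlorophenyl, so this single step is a loose guide to both size and direction. A modest rise in this assay is the most reasonable expectation, although it may not clear the scatter. The expected step is a 1.4-fold higher number from compound 1 to compound 3 (0.16 log units; within the scatter). For compound 3 the estimated value is 5000 nM, with an expected range from 1800 nM to 14000 nM.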

Compound 3, concentration for 50% growth inhibition: 21400 nM
Compound 3: the middle estimate sits 4.3-fold (0.63 log units) below what was measured, and the stated range ends below it.
By their numbers in this assay, from the lowest: compound 1; then compounds 2 and 3 (each within the scatter of the next).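

In this assay, a second and quite different group on this carbon with a double bond to nitrogen also gives weaker growth inhibition than the 2-hydroxyphenyl of compound 1 (a 6.2-fold higher number from compound 1 to compound 3 (0.79 log units; beyond the scatter)). The loss therefore appears with 2,4-dichlorophenyl as well as with 2,6-dimethoxyphenyl, and 2-hydroxyphenyl holds the lowest number of the three groups, with both of its steps beyond the scatter. The two replacements themselves cannot be told apart (a 1.7-fold higher number from compound 2 to compound 3 (0.23 log units; within the scatter)), and nothing measured here explains the loss seen with either of them.

The compounds shown leave open whether the hydroxyl group of compound 1 is what matters, or whether any added groups on this ring, such as chlorine atoms or methoxy groups, are what raise the number. A plain phenyl ring with no added group, or an aminophenyl ring in the same place on the otherwise unchanged core of compound 1, would help to separate these two readings.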